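The compounds below may be only part of what the source reports. "The series", "measured", "known", "first", "only" and "open" are said of these compounds alone.

Measured compounds in a functional assay on A549 cells (Homo sapiens) for inhibition, read by MTT assay, with a stated time of 48 h; a higher number here means a weaker inhibitor, a lower number a stronger inhibitor:
- compound 1 `COc1ccc2c(=O)c(/C=C/C(=O)Nc3cc(C)ccc3C)coc2c1` gives 15500 nM
- compound 2 `COc1ccc2c(=O)c(/C=C/C(=O)NCc3ccc(F)cc3)coc2c1` reaches only the limit of the assay, > 100000 nM
- compound 3 `Cc1ccc(CNC(=O)/C=C/c2coc3cc(O)ccc3c2=O)cc1` gives 17400 nM

Compound 1 has the lowest of the two numbers that are numbers; compound 3 sits within the scatter of it, so no order between the two can be read. Going by the values given here, the one value for compound 2 is a limit, and the limit of > 100000 nM in this assay, at which 1 of the 3 values shown sits, marks it as such.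

The unmeasured compound 4 `CCOc1ccc(NC(=O)/C=C/c2coc3cc(OC)ccc3c2=O)cc1` differs from compound 1 in one place: 4-ethoxyphenyl in place of 2,5-dimethylphenyl on an amide-type nitrogen. Among the compounds with values here, the only measured step touching this amide-type nitrogen is an at least 6.4-fold higher number from compound 1 to compound 2 (0.80 log units; beyond the scatter), which swapped the aryl for a benzyl group and pushed the value to the limit. Within the data shown here, compound 4 keeps an aryl group directly on the nitrogen, so that step bears only loosely on it; no measured pair compares two different aryl groups at this position. With one informative step, and that one of a different kind, the expected outcome is a number near that of compound 1, with the possibility of some loss left open.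

Compound 4 is therefore estimated at 22000 nM in this assay, range 7000 nM to 70000 nM. This means an expected step of a 1.4-fold higher number from compound 1 to compound 4 (0.15 log units; within the scatter), not clearly beyond the scatter.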

Compound 4, half-maximal inhibitory concentration: > 100000 nM
Compound 4: only a limit was reported; the forecaster's own chance of this, stated with the estimate: 20%; at least 4.5-fold (0.65 log units) between middle value and limit.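

In this assay, 4-ethoxyphenyl in place of 2,5-dimethylphenyl on the amide-type nitrogen gives an at least 6.4-fold higher number from compound 1 to compound 4 (0.80 log units; beyond the scatter), so keeping an aryl group directly on this nitrogen is not enough to retain a measurable value. The value of compound 4, > 100000 nM, is a limit, so this step gives only a minimum size for the change. The one earlier step at this nitrogen replaced the aryl group with a benzyl group, and a change of the aryl group alone now leads to the same end, with compound 2 and compound 4 both at: the limit of > 100000 nM in this assay, at which 2 of the 4 values shown sit.

The step between compound 2 and compound 4 cannot be read, as both values are limits. The compounds shown do not separate the effect of adding the 4-ethoxy group from that of removing the two methyl groups, and a 2-methylphenyl, 4-methoxyphenyl or 4-aminophenyl group on this nitrogen would be needed to tell which part of the change matters.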